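Working notes: from compound 3 to compound 4

The compounds below may be only part of what the source reports. "The series", "measured", "known", "first", "only" and "open" are said of these compounds alone.

Values so far in an ADME assay on HEK-293T cells (Homo sapiens) for cytotoxicity, read by MTT assay, with a stated time of 3 days; on this read-out higher numbers stand for lower toxicity in this test and lower numbers for higher toxicity in this test
- compound 1 `CC(C)(C)NC(=O)COC(=O)c1ccc([N+](=O)[O-])o1` gives > 100000 nM as a limit
- compound 2 `CC(C)(C)N(CCC(=O)c1ccccc1)C(=O)COC(=O)c1ccc([N+](=O)[O-])o1` gives "not active" (no number reported)
- compound 3 `CC(C)(C)N(Cc1ccc(OCc2ccccc2)cc1)C(=O)COC(=O)c1ccc([N+](=O)[O-])o1` gives "not active" (no number reported)

Compound 3 has no single number, and its entry in this assay reads "not active" (no number reported) without a value. Compound 2 likewise has no number ("not active" (no number reported)). For compound 1 the entry (> 100000 nM) is a limit and not a number. Going by the values given here, the only numeric reference is therefore the limit of > 100000 nM in this assay, at which 1 of the 3 values shown sits, and no measured pair gives a step size.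

The next structure is compound 4 `CC(C)(C)N(Cc1ccc(F)cc1)C(=O)COC(=O)c1ccc([N+](=O)[O-])o1` and it remains to be measured. The change runs fluoro in place of benzyloxy on an aromatic carbon and puts fluoro in place of benzyloxy on an aromatic carbon, para to a large group.

No step beyond the scatter is expected in this assay in either direction, an expectation resting on compound 3 ("not active" (no number reported)) alone and so tentative. Compound 4 is estimated at 100000 nM with an expected range from 30000 nM to 200000 nM and the assay may well report only a limit.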

Compound 4, half-maximal cytotoxic concentration: > 100000 nM
Compound 4 was reported as a limit; the forecaster's own chance of this, stated with the estimate: 70%; the middle value lies on the limit itself.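

In this assay compound 1 and compound 4 are both entered as limits and compound 3 carries no number, and no step can be read among them. The compounds shown leave open whether any substituent on the amide-type nitrogen changes the half-maximal cytotoxic concentration.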